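The source may report more compounds than this note shows. Statements on the series, on what has been measured and on what is new or still open speak of the compounds shown alone.

Of the compounds shown here, three from this series have been measured in an ADME assay on CCRF-CEM cells (Homo sapiens) for antiproliferative activity, with a stated time of 48 h; a lower number here means a stronger inhibitor, a higher number a weaker inhibitor. Compound 1 `C=C(Br)C(=O)Nc1ccc(/C=C/C(=O)c2ccc(OC)cc2)cc1` gives 1400 nM in this assay. Compound 2 `C=C(Br)C(=O)Nc1ccc(/C=C/C(=O)c2cccc(OC)c2)cc1` differs from compound 1 by 3-methoxyphenyl in place of 4-methoxyphenyl on a carbonyl carbon; in this assay compound 2 gives 2300 nM, a step of a 1.6-fold higher number from compound 1 to compound 2 (0.22 log units; within the scatter). Compound 3 `C=C(Br)C(=O)Nc1ccc(C(=O)/C=C/c2ccc(OC)cc2)cc1` is built on a core whose difference from that of compound 1 is not broken down here; in this assay compound 3 gives 1100 nM, a lower number than that of compound 2, while compound 1 and compound 3 lie close together.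

Compound 4 `C=C(Br)C(=O)Nc1ccc(C(=O)/C=C/c2cccc(OC)c2)cc1` is not yet measured. It differs from compound 3 by 3-methoxyphenyl in place of 4-methoxyphenyl on a double-bonded chain carbon bound to a double-bonded chain carbon. This is the same kind of change as that from compound 1 to compound 2, but not the same: there the group sat on a carbonyl carbon whose other neighbour is a double-bonded chain carbon, here it sits on a double-bonded chain carbon bound to a double-bonded chain carbon. Since the earlier step was a 1.6-fold higher number from compound 1 to compound 2 (0.22 log units; within the scatter), the expected step for compound 4 is a 1.6-fold higher number from compound 3 to compound 4 (0.21 log units; within the scatter), resting on that single precedent and on compound 3 giving 1100 nM. Compound 4 is therefore estimated at 1800 nM in this assay, expected to fall between 900 nM and 3600 nM.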

Compound 4, half-maximal inhibitory concentration: 1800 nM
Compound 4: middle estimate and measured number agree at the digits printed; the measured number falls inside the stated range.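

In this assay the exchange of 4-methoxyphenyl for 3-methoxyphenyl on a double-bonded chain carbon bound to a double-bonded chain carbon gives a 1.6-fold higher number from compound 3 to compound 4 (0.21 log units; within the scatter). The exchange thus reads the same on both cores, and the two steps agree closely: the same change on two cores in this assay, a 1.6-fold higher number (0.22 log units; within the scatter) from compound 1 to compound 2 and a 1.6-fold higher number (0.21 log units; within the scatter) from compound 3 to compound 4, 1.0-fold (0.00 log units) apart, within the scatter of two such steps. Among these compounds, since each step lies within the scatter, this agreement shows only that the exchange carries over between these two cores without a clear difference, not that it has a real effect on either core, and two cores built from the same pieces are too narrow a base for a rule across the series.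

The compounds shown leave open how a 2-methoxyphenyl, a 4-hydroxyphenyl or a 4-dimethylaminophenyl group would read on either core, and whether the two cores would still agree with those groups. They also leave open what follows when the bromine is exchanged for a chlorine or a hydrogen.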